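Shifting a Trifluoromethyl Group on a Shared Core

The source may hold more compounds than are shown below. What is called first, only, known or untested is meant among the compounds shown, and "the series" means these compounds.

Three compounds were measured in a functional assay on HCT-15 cells (Homo sapiens) for inhibition; a higher number here means a weaker inhibitor, a lower number a stronger inhibitor. Compound 1 `Oc1cccc(-c2cc(-c3ccccc3C(F)(F)F)cc(-c3cccc(O)c3)n2)c1` gives 8150 nM. Compound 2 `Oc1cccc(-c2cc(-c3cccc(C(F)(F)F)c3)cc(-c3cccc(O)c3)n2)c1` carries 3-(trifluoromethyl)phenyl in place of 2-(trifluoromethyl)phenyl on an aromatic carbon, and the change gives a 1.7-fold higher number from compound 1 to compound 2 (0.22 log units; within the scatter). Compound 3 `Oc1ccc(-c2cc(-c3ccccc3C(F)(F)F)cc(-c3cccc(O)c3)n2)cc1` carries 4-hydroxyphenyl in place of 3-hydroxyphenyl on an aromatic carbon, and that change gives a 1.4-fold lower number from compound 1 to compound 3 (0.15 log units; within the scatter). Compound 3 thus gives 5740 nM, while compound 2 gives 13600 nM.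

Compound 4 `Oc1ccc(-c2cc(-c3cccc(C(F)(F)F)c3)cc(-c3cccc(O)c3)n2)cc1` has not yet been measured. It differs from compound 3 by 3-(trifluoromethyl)phenyl in place of 2-(trifluoromethyl)phenyl on an aromatic carbon. Going by the values given here, this is the same kind of change as the one from compound 1 to compound 2, though the surroundings differ: in the earlier pair the place is meta to two 3-hydroxyphenyl groups, whereas here it is meta to a 3-hydroxyphenyl group and meta to a 4-hydroxyphenyl group. The two cores differ as told by the change from compound 1 to compound 3.

Among the compounds with values here, from compound 3 to compound 4 a step of a 1.7-fold higher number from compound 3 to compound 4 (0.22 log units; within the scatter) is expected in this assay because a 1.7-fold higher number from compound 1 to compound 2 (0.22 log units; within the scatter) is the only observed instance of this change. Compound 4 is therefore estimated at 9500 nM, likely between 4500 nM and 20000 nM.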

Compound 4, half-maximal inhibitory concentration: 9540 nM
Compound 4: middle estimate off by 1.0-fold (0.00 log units), on the low side; the range from low to high includes it.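

In this assay, going by these compounds alone, the shift of the trifluoromethyl group repeats on the second core, with a 1.7-fold higher number from compound 3 to compound 4 (0.22 log units; within the scatter), and the two steps agree: the same change on two cores in this assay, a 1.7-fold higher number (0.22 log units; within the scatter) from compound 1 to compound 2 and a 1.7-fold higher number (0.22 log units; within the scatter) from compound 3 to compound 4, 1.0-fold (0.00 log units) apart, within the scatter of two such steps The exchange of the hydroxyphenyl group also repeats when read on the other core, with a 1.4-fold lower number from compound 2 to compound 4 (0.15 log units; within the scatter), and again the steps agree: the same change on two cores in this assay, a 1.4-fold lower number (0.15 log units; within the scatter) from compound 1 to compound 3 and a 1.4-fold lower number (0.15 log units; within the scatter) from compound 2 to compound 4, 1.0-fold (0.00 log units) apart, within the scatter of two such steps Across these four compounds, each change therefore carries from one core to the other with no visible difference, but every one of these steps lies within the scatter, so the agreement shows only that neither change moved the number measurably on either core, not that either change has a real effect or that a larger step would carry over in the same way.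

The compounds shown leave open whether this holds for other groups, such as a nitrile or a chlorine in place of the trifluoromethyl, or an amine or a carboxylic acid in place of the hydroxyl. They also leave open whether a change with a step beyond the scatter would transfer as cleanly between these cores.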